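The compounds below may be only part of what the source reports. "The series", "measured", "known", "first", "only" and "open" are said of these compounds alone.

Of the compounds shown here, three of a shared core have been measured in a functional assay on HeLa cells (Homo sapiens) for cytotoxicity, read by MTT assay, with a stated time of 72 h; a higher number here means a weaker inhibitor, a lower number a stronger inhibitor. Compound 1 `CCOc1ccc2cc(C(=O)NCCO)c(=O)oc2c1` reaches only a limit of the assay, > 100000 nM. Compound 2 `O=C(NCCO)c1cc2ccc(OCc3ccccc3)cc2oc1=O` gives 14200 nM, and compound 3 `O=C(NCCO)c1cc2ccc(OCc3cccc(Br)c3)cc2oc1=O` gives 17600 nM. Among the two plain numbers, compound 2 stands lowest, but its step to compound 3 is a 1.2-fold higher number from compound 2 to compound 3 (0.09 log units; within the scatter), so the two cannot be told apart. The steps that exceed the scatter both start from the limit of compound 1: an at least 7.0-fold lower number from compound 1 to compound 2 (0.84 log units; beyond the scatter) and an at least 5.6-fold lower number from compound 1 to compound 3 (0.75 log units; beyond the scatter), each changing the group on the saturated chain carbon bound to the oxygen on the aromatic ring.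

Compound 4 `O=C(Nc1ccccc1)c1cc2ccc(OCc3ccccc3)cc2oc1=O` is not yet measured. It differs from compound 2 at another place: phenyl in place of 2-hydroxyethyl on an amide-type nitrogen. None of the measured steps touches the amide-type nitrogen, so nothing shown bears directly on this change. The expectation for compound 4 therefore rests on compound 2 alone and carries wide uncertainty, with the step estimated as a 1.2-fold lower number from compound 2 to compound 4 (0.07 log units; within the scatter). Compound 4 is thus expected to give about 12000 nM, within 2500 nM to 60000 nM.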

Compound 4, half-maximal inhibitory concentration: > 100000 nM
Compound 4: a limit, no number; the forecaster's own chance of this, stated with the estimate: 15%; middle value at least 8.3-fold (0.92 log units) from the limit.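

The earlier compounds shown here varied only the group on the saturated chain carbon bound to the oxygen on the aromatic ring, whereas this change shows that in this assay the amide-type nitrogen counts as well, with an at least 7.0-fold higher number from compound 2 to compound 4 (0.84 log units; beyond the scatter). Compound 4 sits at a limit of the assay rather than at a number, so this step gives only the smallest possible size of the change: the limit of > 100000 nM in this assay, at which 2 of the 4 values shown sit. The same phenyl group also goes with opposite outcomes at the two places, with an at least 7.0-fold lower number from compound 1 to compound 2 (0.84 log units; beyond the scatter) on the chain carbon but a higher number on the nitrogen.

On these data alone, whether this rise follows from removing 2-hydroxyethyl or from adding phenyl stays open. A methyl group, a longer chain ending in an amine or one ending in a carboxylic acid on that nitrogen could help separate the two.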